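The source may hold more compounds than are shown below. What is called first, only, known or untested is meant among the compounds shown, and "the series" means these compounds.

Series read in a functional assay on DLD-1 cells (Homo sapiens) for antiproliferative activity, read by CellTiter-Glo, with a stated time of 72 h; on this read-out higher numbers stand for weaker inhibition and lower numbers for stronger inhibition.

Measured compounds:
compound 1, `CC1CCN(C2CCN(S(=O)(=O)c3cccc(C(F)(F)F)c3)CC2)CC1`: > 5000 nM (a limit of the assay)
compound 2, `CC1CCN(C2CCN(S(=O)(=O)c3cccc(N)c3)CC2)CC1`: 3400 nM
compound 3, `COc1ccc(-c2cccc(S(=O)(=O)N3CCC(N4CCC(C)CC4)CC3)c2)cc1`: 23 nM

Compound 3 stands lowest of the two numbers shown; the nearest is compound 2, with a 150-fold lower number from compound 2 to compound 3 (2.17 log units; beyond the scatter). For compound 1 the read-out is only a limit of the assay, (the limit of > 5000 nM in this assay, at which 1 of the 3 values shown sits). From compound 1 the steps are an at least 1.4-fold lower number from compound 1 to compound 2 (0.16 log units; that floor lies within the scatter) and an at least 210-fold lower number from compound 1 to compound 3 (2.33 log units; beyond the scatter); the first lies within the scatter, the second is large.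

Compound 4, `CC1CCN(C2CCN(S(=O)(=O)c3cccc(-c4ccccc4F)c3)CC2)CC1`, differs from compound 3 by 2-fluorophenyl in place of 4-methoxyphenyl on an aromatic carbon.

Among the measured compounds shown here, the steps that bear on this change are the two large ones into compound 3: both bring in 4-methoxyphenyl in place of a small group, and both lower the number by more than two orders. The change to compound 4 keeps an aromatic substituent at that place and only exchanges 4-methoxyphenyl for 2-fluorophenyl. For the measured compounds named here, no measured step separates one such aromatic substituent from another, so the expected step from compound 3 to compound 4 is small, a 2.2-fold higher number from compound 3 to compound 4 (0.34 log units; beyond the scatter), and may fall within the scatter. Compound 4 is therefore estimated at 50 nM, expected between 15 nM and 200 nM.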

Compound 4, half-maximal inhibitory concentration: 10 nM
Beside the measured number, compound 4's estimate is 5.0-fold (0.70 log units) above it; measured number outside the range, below it.
By their numbers in this assay, from the lowest: compound 4; then compound 3; then compound 2. At a limit, above all of these: compound 1.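

In this assay, the exchange of one aromatic substituent for another at this carbon now has a measured size, a 2.3-fold lower number from compound 3 to compound 4 (0.36 log units; beyond the scatter), so the choice of aromatic group still moves the number, modestly, once such a group is present. The large drop from the small groups is also not confined to 4-methoxyphenyl, since 2-fluorophenyl gives a 340-fold lower number from compound 2 to compound 4 (2.53 log units; beyond the scatter) and an at least 500-fold lower number from compound 1 to compound 4 (2.69 log units; beyond the scatter), which makes two aromatic substituents that both sit far below the amino and trifluoromethyl compounds. The read-out of compound 1 is only a limit of the assay, so the second of these steps is a floor: the limit of > 5000 nM in this assay, at which 1 of the 4 values shown sits.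

The pair compound 3 and compound 4 changes the substituent on the aromatic group and its place on that ring together, so the two effects cannot be separated; a plain phenyl on the same carbon would be the direct reference. On these data alone, whether the drop needs an aromatic ring of carbon only also stays open, and a pyridyl ring, a morpholine or a carboxylic acid at this place would bear on that.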